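This account rests on a few compounds, and the source may have more. Where it says the series, first, only, none or still open, it means among the compounds named here.

Measured so far in a functional assay on HeLa cells (Homo sapiens) for cytotoxicity, read by cell counting, with a stated time of 4 days; a higher number here means a weaker inhibitor, a lower number a stronger inhibitor: compound 1 `Nc1ccc(/C=C2\SC(=O)N(Cc3ccc(F)cc3)C2=O)cc1` gives 186000 nM; compound 2 `Nc1ccc(/C=C2\SC(=O)N(Cc3ccc(Cl)cc3)C2=O)cc1` gives 77000 nM; compound 3 `C=C(Br)C(=O)Nc1ccc(/C=C2\SC(=O)N(C)C2=O)cc1` gives 870 nM.

Compound 3 stands lowest of the three numbers, well beyond the scatter from both compound 1 and compound 2. The next compound, compound 4 `CN1C(=O)S/C(=C\c2ccc(N)cc2)C1=O`, differs from compound 3 by hydrogen in place of (1-bromoethenyl)carbonyl on a nitrogen on an aromatic ring. Among the compounds with values here, no measured step covers this change; the only step in hand, a 2.4-fold lower number from compound 1 to compound 2 (0.38 log units; beyond the scatter), concerns a different position and does not bear on it. What compounds 1 and 2 show is that both carry the free amino and both sit far up in the numbers. The expected step in this assay is therefore a large rise, a 92-fold higher number from compound 3 to compound 4 (1.96 log units; beyond the scatter). Compound 4 is estimated at 80000 nM, range 15000 nM to 300000 nM.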

Compound 4, half-maximal inhibitory concentration: 97000 nM
The estimate for compound 4 lay 1.2-fold (0.08 log units) below the measured number; measured number inside the range.
By their numbers in this assay, from the lowest: compound 3; then compounds 2, 4 and 1 (each within the scatter of the next, the first and the last beyond it).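

In this assay, hydrogen in place of (1-bromoethenyl)carbonyl on the nitrogen gives a 110-fold higher number from compound 3 to compound 4 (2.05 log units; beyond the scatter) and so ties the low number of compound 3 to that group. Hydrogen in place of 4-chlorophenyl gives a 1.3-fold higher number from compound 2 to compound 4 (0.10 log units; within the scatter) and hydrogen in place of 4-fluorophenyl gives a 1.9-fold lower number from compound 1 to compound 4 (0.28 log units; within the scatter) so, with the free amino present, these changes stay within the scatter. Nothing in hand explains the large step.

Open, going by these compounds, is whether the bromine or the rest of the group carries the step: a plain acetyl or an acryloyl on the same nitrogen would separate them.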